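Replacing the phenyl with methyl on the core of compound 1

The source may hold more compounds than are shown below. What is called first, only, known or untested is meant among the compounds shown, and "the series" means these compounds.

Compound 1 `C/N=C(\S)NCCCCCn1nc(-c2ccccc2)ccc1=O` stands second highest of the three numbers in a functional assay on the whole organism with Rattus norvegicus as the target, at a dose of 100 mg/kg (a higher number here means more inhibition at the dose given (going by the name of the read-out), a lower number less inhibition), where compound 1 gives 68.9%. Compound 3 `CN(C)/C(=N/CCCn1nc(-c2ccccc2)ccc1=O)NC#N` gives 72.2%, and the step of a number 3.3 percentage points higher from compound 1 to compound 3 (within the scatter) lies within the scatter. Compound 2 `N#CNC(=N)NCCCCCCn1nc(-c2ccccc2)ccc1=O` gives 20.5%, a step of a number 48.4 percentage points lower from compound 1 to compound 2 (beyond the scatter). Compound 4 `C/N=C(\S)NCCCCCn1nc(C)ccc1=O` differs from compound 1 by methyl in place of phenyl on an aromatic carbon. Neither measured step bears on this ring change: both alter the chain terminus, one with a large loss and one with no change beyond the scatter. Lacking a comparable step, the expected outcome is uncertain. Compound 4 is estimated at 50%, with a range from 15% to 80%, meaning an expected step of a number 18.9 percentage points lower from compound 1 to compound 4 (beyond the scatter).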

Compound 4, a percentage reported as inhibition, in the whole organism at one dose (the size of the read-out at that dose, not a potency): 3.2%
Estimate against measurement, compound 4: 46.8 percentage points above; measured number outside the range, below it.
By their numbers in this assay, from the lowest: compound 4; then compound 2; then compounds 1 and 3 (each within the scatter of the next).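

With the chain and its terminus unchanged, the phenyl on this aromatic carbon proves decisive in this assay: replacing it with methyl gives a number 65.7 percentage points lower from compound 1 to compound 4 (beyond the scatter). Going by these compounds alone, the earlier steps changed only the chain end, so this is the first sign that the ring position alone can remove nearly all of the inhibition at this dose. Nothing available accounts for this loss. Going by these compounds, it remains open whether the whole phenyl ring is needed, or whether an ethyl, a cyclohexyl or a pyridyl group at this position would restore the inhibition.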